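Chalcone-type series: methoxy removal on compound 3

This account rests on a few compounds, and the source may have more. Where it says the series, first, only, none or still open, it means among the compounds named here.

Measured compounds:
Compound 1, `O=C(/C=C/c1cn(-c2ccccc2)nc1-c1cccnc1)c1cc[nH]c1`, gives 3300 nM in a functional assay on Huh-7 cells (Homo sapiens) for inhibition, read by sulforhodamine B assay, with a stated time of 72 h; on this read-out higher numbers stand for weaker inhibition and lower numbers for stronger inhibition.
Compound 2, `O=C(/C=C/c1cn(-c2ccccc2)nc1-c1cccnc1)c1c[nH]c2ccccc12`, gives 3200 nM in this assay.
Compound 3, `COc1cc(C(=O)/C=C/c2cn(-c3ccccc3)nc2-c2cccnc2)cc(OC)c1OC`, gives 1900 nM in this assay.

Compound 3 shows the lowest of the three numbers, but its gaps to compound 2 and compound 1 are both within the scatter, so no ordering among the three is claimed. Among the compounds with values here, the one step measured so far, a 1.0-fold lower number from compound 1 to compound 2 (0.01 log units; within the scatter), concerns the aryl group on the carbonyl carbon and not the methoxy pattern.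

Compound 4, `COc1ccc(C(=O)/C=C/c2cn(-c3ccccc3)nc2-c2cccnc2)cc1OC`, differs from compound 3 in one place: hydrogen in place of methoxy on an aromatic carbon. Within the data shown here, no measured step touches a methoxy group, so nothing in the data sets a direction for this change. With the carbonyl-side aryl already shown to tolerate a swap without movement beyond the scatter, the expectation for compound 4 in this assay is a change of a 1.3-fold higher number from compound 3 to compound 4 (0.12 log units; within the scatter), i.e. none beyond the scatter. Compound 4 is therefore estimated at 2500 nM, within 1000 nM to 6500 nM.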

Compound 4, half-maximal inhibitory concentration: 3100 nM
Estimate against measurement, compound 4: 1.2-fold (0.09 log units) below; low and high end bracket the measured number.
By their numbers in this assay, from the lowest: compounds 3, 4, 2 and 1 (each within the scatter of the next).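

In this assay, within the data shown here, the first step at a methoxy position, a 1.6-fold higher number from compound 3 to compound 4 (0.21 log units; within the scatter), stays within the scatter, so this position tolerates hydrogen in place of methoxy without a readable change. The 3,4-dimethoxyphenyl group of compound 4 also matches the other carbonyl-side groups: a 1.0-fold lower number from compound 2 to compound 4 (0.01 log units; within the scatter) against 1H-indol-3-yl and a 1.1-fold lower number from compound 1 to compound 4 (0.03 log units; within the scatter) against 1H-pyrrol-3-yl, both within the scatter, which extends the flat picture on the carbonyl carbon to a third swap. Nothing available explains this flat response.

Open, going by these compounds, is whether an amine, a carboxylic acid or a longer chain such as butoxy at this position would move the number beyond the scatter. Also open, on these data alone, is whether losing the remaining methoxy groups would do so.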